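Swapping the basic side chain of compound 1

This account rests on a few compounds, and the source may have more. Where it says the series, first, only, none or still open, it means among the compounds named here.

Compound 1 `CN1CCN(CCCNCc2cn(-c3ccc([N+](=O)[O-])cc3)nc2-c2ccc(OC(F)(F)F)cc2)CC1` gives 1600 nM in an ADME assay on Huh-7 cells (Homo sapiens) for cytotoxicity (a lower number here means that less compound is tolerated, a higher number that more compound is tolerated), the lowest of the two numbers shown. Among the compounds with values here, compound 2 `CN1CCN(CCCNCc2cn(-c3ccc([N+](=O)[O-])cc3)nc2-c2ccc(Cl)cc2)CC1` gives 3700 nM in this assay, and the step of a 2.3-fold higher number from compound 1 to compound 2 (0.36 log units; beyond the scatter) is the only measured change. Compound 3 `CN1CCN(CCNCc2cn(-c3ccc(F)cc3F)nc2-c2ccccc2)CC1` reaches only a limit in this assay, > 20000 nM (the limit of > 20000 nM in this assay, at which 1 of the 3 values shown sits). Compound 4 `CCCN1CCC(CNCc2cn(-c3ccc([N+](=O)[O-])cc3)nc2-c2ccc(OC(F)(F)F)cc2)CC1` carries a different change: 1-propylpiperidin-4-yl in place of 2-(4-methylpiperazin-1-yl)ethyl on a saturated chain carbon bound to an amine nitrogen. Within the data shown here, no measured step touches this part of the molecule, so the one step available, on the aromatic ring, bears only loosely on it. A modest shift is expected, the direction open. Compound 4 is therefore estimated at 3000 nM, between 1000 nM and 10000 nM. The expected step is a 1.9-fold higher number from compound 1 to compound 4 (0.27 log units; within the scatter).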

Compound 4, half-maximal cytotoxic concentration: 18000 nM
Estimate against measurement, compound 4: 6.0-fold (0.78 log units) below; the measured number lies above the stated range.
By their numbers in this assay, from the lowest: compound 1; then compound 2; then compound 4. At a limit, above all of these: compound 3.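

In this assay, the change on the saturated chain carbon bound to an amine nitrogen matters more than the aromatic change, a 2.3-fold higher number from compound 1 to compound 2 (0.36 log units; beyond the scatter): 1-propylpiperidin-4-yl in place of 2-(4-methylpiperazin-1-yl)ethyl gives an 11-fold higher number from compound 1 to compound 4 (1.05 log units; beyond the scatter). Far more compound is thus tolerated after this swap alone. Nothing measured here explains the shift.

The compounds shown leave open whether the same swap would raise the number for compound 2. They also leave open whether a morpholine ring, or an ethyl group in place of the propyl group, would have a similar effect.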